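A few compounds are considered here, and "the series" means these few. Any claim that something is new, unique, unknown or untested is made for them only; others in the source may bear on it.

In a toxicity assay on KB cells (Homo sapiens) for cytotoxicity, read by fluorescence, with a stated time of 3 days (on this read-out higher numbers stand for an effect only at larger amounts of compound and lower numbers for an effect already at smaller amounts), compound 1 (`CCCCOC(=O)CNC(=O)[C@H](CSc1ccc([N+](=O)[O-])cc1[N+](=O)[O-])NC(=O)CC[C@H](NC(=O)CCC(C)C)C(=O)OCCCC`) gives 84 uM. Compound 2 (`CCCCOC(=O)CNC(=O)[C@H](CSc1ccc([N+](=O)[O-])cc1[N+](=O)[O-])NC(=O)CC[C@H](NC(C)=O)C(=O)OCCCC`) gives > 300 uM, which is a limit of the assay and not a number. Compound 3 (`CCCCCCCCCCCCCC(=O)N[C@@H](CCC(=O)N[C@@H](CSc1ccc([N+](=O)[O-])cc1[N+](=O)[O-])C(=O)NCC(=O)OCCCC)C(=O)OCCCC`) differs from compound 2 at one place: dodecyl in place of hydrogen on a saturated chain carbon bound to a carbonyl carbon. It carries dodecyl in place of hydrogen on a saturated chain carbon bound to a carbonyl carbon.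

Among the measured compounds shown here, one measured step bears on this change: an at least 3.5-fold higher number from compound 1 to compound 2 (0.55 log units; beyond the scatter). There, hydrogen takes the place of isobutyl on a saturated chain carbon bound to a carbonyl carbon, so that step runs the opposite way to the new change. Read in reverse, it leads to the expectation of a lower number in this assay, beyond the scatter, although it sets only a minimum size and the true size remains open. The expected step is an at least 15-fold lower number from compound 2 to compound 3 (1.17 log units; beyond the scatter). Compound 3 is estimated at 20 uM, with an expected range of 4 uM to 90 uM.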

Compound 3, concentration for half-maximal effect: > 300 uM
Compound 3 was reported as a limit; the forecaster's own chance of this, stated with the estimate: 10%; middle value at least 15-fold (1.17 log units) away from the limit.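

In this assay compound 3 gives > 300 uM, which is a limit of the assay and not a number. A longer chain at this place therefore does not simply bring a lower number: undecyl in place of isopropyl on a saturated chain carbon, two bonds along the chain from a carbonyl carbon, gives an at least 3.5-fold higher number from compound 1 to compound 3 (0.55 log units; beyond the scatter). The step between compound 2 and compound 3 cannot be read, and the only measured number among these compounds stays with the isobutyl chain of compound 1, as the comparison ends at a shared limit: the limit of > 300 uM in this assay, at which 2 of the 3 values shown sit.

The compounds shown leave open how chains of intermediate length, such as hexyl or octyl, behave at this place, and whether any of them gives a number under that limit. They also leave open what an amine or a carboxylic acid at the end of the chain would do.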